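This account rests on a few compounds, and the source may have more. Where it says the series, first, only, none or still open, it means among the compounds named here.

Measured compounds:
compound 1, `COc1ccc(/C=C/S(=O)(=O)Nc2ccc(F)cc2)cc1`, 10000 nM in a functional assay on K562 cells (Homo sapiens) for cytotoxicity, read by trypan blue exclusion, with a stated time of 96 h; on this read-out lower numbers stand for stronger inhibition and higher numbers for weaker inhibition
compound 2, `COc1ccc(/C=C/S(=O)(=O)Nc2ccc(OC)cc2)cc1`, 5000 nM
compound 3, `COc1cc(OC)c(/C=C/S(=O)(=O)Nc2ccc(OC)c([N+](=O)[O-])c2)c(OC)c1`, 1000 nM

Compound 3 has the lowest number of the three, and its gap to compound 2 and to compound 1 is beyond the scatter in each case. How the core of compound 3 differs from that of compound 2 is not broken down here. Between compound 2 and compound 1 one change is made, (fluoro in place of methoxy on an aromatic carbon), and it gives a 2.0-fold higher number from compound 2 to compound 1 (0.30 log units; within the scatter).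

Compound 4, `COc1cc(OC)c(/C=C/S(=O)(=O)Nc2ccc(F)c([N+](=O)[O-])c2)c(OC)c1`, is not yet measured. It stands to compound 3 as compound 1 stands to compound 2: fluoro in place of methoxy on an aromatic carbon. The two place lines are not the same word for word; for compound 3 to compound 4 the aromatic carbon is also ortho to a nitro group, so this is the same kind of change, not the same change. In this assay, going by the values given here, the expected step is a 2.0-fold higher number from compound 3 to compound 4 (0.30 log units; within the scatter), and it rests on a single earlier step because a 2.0-fold higher number from compound 2 to compound 1 (0.30 log units; within the scatter) is the only measured step in which this change is seen. Compound 4 is therefore estimated at 2000 nM, with a likely range from 800 nM to 5000 nM.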

Compound 4, half-maximal inhibitory concentration: 75000 nM
Estimate against measurement, compound 4: 38-fold (1.57 log units) below, outside the stated range (above it).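

In this assay, fluoro in place of methoxy on an aromatic carbon gives a 75-fold higher number from compound 3 to compound 4 (1.88 log units; beyond the scatter), and the step seen on the earlier core does not carry over to this one: the same change on two cores in this assay, a 2.0-fold higher number (0.30 log units; within the scatter) from compound 2 to compound 1 and a 75-fold higher number (1.88 log units; beyond the scatter) from compound 3 to compound 4, 38-fold (1.57 log units) apart, beyond the scatter of two such steps This shows that, in this series, the change cannot be moved from one core to another as a step of fixed size, and that a result on the core of compound 2 is a poor guide to what happens on the core of compound 3. Going by these compounds alone, it does not show which difference between the cores sets the size of the step, whether the nitro group, ortho to the changed aromatic carbon in compound 4, or the further methoxy groups of the core of compound 3, and each core offers only one pair of compounds.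

Among the compounds shown, the nitro group and the further methoxy groups always occur together, so the share of each in the larger step remains open. Also open, as far as these compounds go, is how chloro, methyl or hydroxy would behave on the same aromatic carbon, and whether an amine in place of the nitro group would bring the two steps closer together.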